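A few compounds are considered here, and "the series" means these few. Any claim that something is new, unique, unknown or untested is made for them only; others in the source may bear on it.

Measured in an ADME assay on MDBK cells (Bos taurus) for cytotoxicity, read by MTT assay, with a stated time of 96 h; on this read-out lower numbers stand for higher toxicity in this test and higher numbers for lower toxicity in this test:
- Compound 1 `COc1ccc(-c2nc3cc(C(C)=O)ccc3[nH]2)c(OC)c1`: 73000 nM
- Compound 2 `COc1ccc(-c2nc3cc(C(C)=O)ccc3n2C2CCCCC2)cc1`: > 100000 nM

Compound 2 gives only a limit of this assay, > 100000 nM, and not a number.

Compound 3 `COc1ccc(-c2nc3cc(C(C)=O)ccc3n2C2CCCCC2)c(OC)c1` differs from compound 2 in one place: methoxy in place of hydrogen on an aromatic carbon, ortho to a large group and meta to a methoxy group (methoxy in place of hydrogen on an aromatic carbon).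

Within the data shown here, no measured pair isolates this change, so the expectation is tentative. Compound 3 shares the added methoxy with compound 1, which gives 73000 nM, though the two differ elsewhere. The expected step of an at least 1.1-fold lower number from compound 2 to compound 3 (0.07 log units; that floor lies within the scatter) is small, towards lower numbers if it moves at all, and may stay within the scatter. The assay may again report only a limit. For compound 3 the estimated value is 85000 nM, with an expected range of 35000 nM to 100000 nM.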

Compound 3, half-maximal cytotoxic concentration: 21000 nM
Estimate against measurement, compound 3: 4.0-fold (0.61 log units) above; measured number below the stated range.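

In this assay, methoxy in place of hydrogen on the aromatic carbon ortho to a large group gives an at least 4.7-fold lower number from compound 2 to compound 3 (0.67 log units; beyond the scatter), so this single change moves the read-out beyond the scatter, towards higher toxicity in this test. That step is only a minimum, because compound 2 has a limit and not a number: the limit of > 100000 nM in this assay, at which 1 of the 3 values shown sits. The cyclohexyl on the aromatic nitrogen matters as well once this methoxy is present, with a 3.5-fold lower number from compound 1 to compound 3 (0.54 log units; beyond the scatter).

As far as these compounds go, it remains open whether another group on this aromatic carbon, such as a hydroxy group or a chlorine atom, would shift the read-out as methoxy does. From the compounds shown here alone, it is also open whether a methyl group or an open chain on the nitrogen would act as cyclohexyl does, and these compounds give no reason for either step.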